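Dropping the chloro from a hydrazone series

The compounds below may be only part of what the source reports. "The series", "measured", "known", "first", "only" and "open" are said of these compounds alone.

Compound 1 `Clc1ccc(C(/C=C/c2ccccc2)=N\Nc2nncc3ccccc23)cc1` gives 0.07 nM in a functional assay on SK-OV-3 cells (Homo sapiens) for antiproliferative activity, read by sulforhodamine B assay, with a stated time of 72 h; a lower number here means a stronger inhibitor, a higher number a weaker inhibitor. Compound 2 `NC(=S)NNc1nncc2ccccc12` gives 0.8 nM. Compound 3 `O=S(=O)(Nc1ccccn1)c1ccc(Nc2nncc3ccccc23)cc1` gives 0.9 nM.

Compound 1 stands at the lowest number of the three, and its gaps to compound 2 and compound 3 both lie beyond the usual scatter. Compound 4 `C(=C/c1ccccc1)\C(=N\Nc1nncc2ccccc12)c1ccccc1` is not yet measured. It differs from compound 1 in one place: hydrogen in place of chloro on an aromatic carbon, turning 4-chlorophenyl into phenyl. Among the compounds with values here, no step between measured compounds matches this change, so the outlook rests on compound 1 alone. A modest loss is expected: the step of a 2.9-fold higher number from compound 1 to compound 4 (0.46 log units; beyond the scatter) should raise the number somewhat, while remaining well below the other two. Compound 4 is estimated at 0.2 nM, within 0.05 nM to 1 nM.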

Compound 4, half-maximal inhibitory concentration: 0.01 nM
Estimate against measurement, compound 4: 20-fold (1.30 log units) above, outside the stated range (below it).
By their numbers in this assay, from the lowest: compound 4; then compound 1; then compounds 2 and 3 (each within the scatter of the next).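

Taking the chloro off the aromatic carbon does not cost activity in this assay, since the change from 4-chlorophenyl to phenyl gives a 7.0-fold lower number from compound 1 to compound 4 (0.85 log units; beyond the scatter). Within the data shown here, the chlorine is therefore not needed at this place for the low number of compound 1, a point that the earlier compounds, with no matched pair among them, could not address. Nothing in the data explains why the number falls.

Only chloro and hydrogen are shown on this carbon. On these data alone, how a fluoro, a methyl, a methoxy or an amine would read there remains open.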